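This account rests on a few compounds, and the source may have more. Where it says the series, first, only, none or still open, it means among the compounds named here.

Compound 1 `Cc1c(Cc2ccccc2)c(=O)oc2cc(OCC(O)CNCc3ccccc3)ccc12` sits at the limit of > 100000 nM in this assay, at which 1 of the 3 values shown sits; in an ADME assay on A549 cells (Homo sapiens) for cytotoxicity, read by CellTiter-Glo (a lower number here means that less compound is tolerated, a higher number that more compound is tolerated), compound 1 gives > 100000 nM, which is a limit of the assay and not a number. Compound 2 `Cc1c(Cc2ccc(C(C)(C)C)cc2)c(=O)oc2cc(OCC(O)CN3CCC(C(N)=O)CC3)ccc12` gives 14700 nM in this assay, and compound 3 `Cc1c(Cc2ccc(Cl)cc2)c(=O)oc2cc(OCC(O)CN3CCC(C(N)=O)CC3)ccc12` gives 40000 nM. Among the measured compounds shown here, the single measured step between these two, a 2.7-fold higher number from compound 2 to compound 3 (0.43 log units; beyond the scatter), is modest. Among the two numbers known, compound 3 holds the higher one, with compound 2 as its nearest neighbour and compound 1 contributing only a limit.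

Compound 4 `Cc1c(Cc2ccc(F)cc2F)c(=O)oc2cc(OCC(O)CN3CCC(C(N)=O)CC3)ccc12` differs from compound 3 in one place: 2,4-difluorophenyl in place of 4-chlorophenyl on a saturated chain carbon bound to an aromatic carbon. For the measured compounds named here, the only measured step that touches the same ring is the exchange of one substituent for another on that ring, which moved the result from compound 2 to compound 3 by a modest amount. A swap of halogens on the same ring is a change of similar kind, so a step of similar or smaller size, possibly within the scatter, is expected here; the step of a 1.1-fold higher number from compound 3 to compound 4 (0.05 log units; within the scatter) is what this estimate means. Compound 4 is therefore estimated in this assay at 45000 nM, with a range from 15000 nM to 100000 nM.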

Compound 4, half-maximal cytotoxic concentration: > 100000 nM
Compound 4 ended at the assay's limit (the forecaster's own chance of this, stated with the estimate: 25%); at least 2.2-fold (0.34 log units) between middle value and limit.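

In this assay, the ring on the saturated chain carbon bound to an aromatic carbon proves sensitive to a change between halogens, not only to the loss of a large tert-butyl group: 2,4-difluorophenyl in place of 4-chlorophenyl gives an at least 2.5-fold higher number from compound 3 to compound 4 (0.39 log units; beyond the scatter). Measured against the tert-butyl compound, the same position gives an at least 6.8-fold higher number from compound 2 to compound 4 (0.83 log units; beyond the scatter), so among these three compounds, which differ only in this group, the order runs from 4-(tert-butyl)phenyl through 4-chlorophenyl to 2,4-difluorophenyl, with none going against it. Compound 4 gives a limit rather than a number, so both steps show only a minimum size and the real distance remains unknown: the limit of > 100000 nM in this assay, at which 2 of the 4 values shown sit.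

The compounds shown do not separate the effect of replacing chlorine with fluorine from that of adding a second halogen, and a 4-fluorophenyl group or a plain phenyl on the same side chain would address that question. Compound 1 also sits at the limit, but it differs from the others in more than one place, so its result cannot be assigned to any single group.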